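Variation at the chlorinated aromatic carbon of the nucleoside series

A few compounds are considered here, and "the series" means these few. Any claim that something is new, unique, unknown or untested is made for them only; others in the source may bear on it.

Measured so far:
compound 1 `OC[C@H]1OC(n2cnc3c(S)nccc32)[C@H](O)[C@@H]1O` – 6%
compound 2 `OC[C@H]1OC(n2cnc3c(Cl)nccc32)[C@H](O)[C@@H]1O` – 76%

In a functional assay (Homo sapiens) for inhibition of Nucleic Acid, tested at 100 uM (on this read-out lower numbers stand for less inhibition and higher numbers for more inhibition at the one concentration tested (going by the name of the read-out)), compound 2 stands highest of the two numbers; compound 1 is the nearest, with a number 70 percentage points higher from compound 1 to compound 2 (beyond the scatter) separating them. Compound 3 `[N-]=[N+]=Nc1nccc2c1ncn2C1O[C@H](CO)[C@@H](O)[C@H]1O` differs from compound 2 in one place: azido in place of chloro on an aromatic carbon. Among the compounds with values here, no measured step swaps chloro for azido, so the only bearing step is the large one from compound 1 to compound 2, which shows this position moves inhibition strongly. Direction for compound 3 is uncertain; a moderate drop is expected, a number 31 percentage points lower from compound 2 to compound 3 (beyond the scatter), giving an estimate of 45% with a range from 10% to 80%.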

Compound 3, a percentage reported as inhibition, at one concentration (the size of the read-out at that concentration, not a potency): 4%
Estimate against measurement, compound 3: 41 percentage points above; measured number below the stated range.
By their numbers in this assay, from the lowest: compounds 3 and 1 (each within the scatter of the next); then compound 2.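

In this assay azido in place of chloro gives a number 72 percentage points lower from compound 2 to compound 3 (beyond the scatter) and so a second group, after sulfanyl, goes with almost no inhibition at this aromatic carbon. Within the data shown here, with a number 2 percentage points lower from compound 1 to compound 3 (within the scatter) azido and sulfanyl cannot be told apart, which leaves chloro as the only one of the three groups with clear inhibition at this position. Nothing at hand bears on the reason for this.

Open, going by these compounds, is whether bromo, methoxy or an amine at this carbon would keep the inhibition of compound 2 or fall to the level of compound 1 and compound 3.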